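Compound 3 and a new aryl group on nitrogen

This account rests on a few compounds, and the source may have more. Where it says the series, first, only, none or still open, it means among the compounds named here.

In a functional assay on MKN-45 cells (Homo sapiens) for inhibition, read by CCK-8 assay, with a stated time of 24 h (a higher number here means a weaker inhibitor, a lower number a stronger inhibitor), the measured compounds read as follows:
Compound 1 `O=C1Nc2ccccc2/C1=C/c1ccc(-c2cn(-c3ccccc3F)nn2)cc1` gives 12500 nM in this read-out
Compound 2 `O=C1Nc2ccccc2/C1=C/c1ccc(-c2cn(-c3cccc(F)c3)nn2)cc1` gives > 20000 nM as a limit of the assay, not a number
Compound 3 `O=C1Nc2ccc(F)cc2/C1=C/c1ccc(-c2cn(-c3cccc(F)c3)nn2)cc1` gives 8190 nM in this read-out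

Of the two true numbers, those of compound 3 and compound 1 lie within the scatter of each other. Compound 4 `O=C1Nc2ccc(F)cc2/C1=C/c1ccc(-c2cn(-c3ccc(Cl)c(C(F)(F)F)c3)nn2)cc1` carries 4-chloro-3-(trifluoromethyl)phenyl in place of 3-fluorophenyl on an aromatic nitrogen and otherwise matches compound 3.

Within the data shown here, two measured steps bear on this change. On that same nitrogen, 3-fluorophenyl in place of 2-fluorophenyl gave an at least 1.6-fold higher number from compound 1 to compound 2 (0.20 log units; that floor lies within the scatter) and so shows no change beyond the scatter. Fluoro in place of hydrogen on the core gave an at least 2.4-fold lower number from compound 2 to compound 3 (0.38 log units; beyond the scatter) but lies elsewhere in the molecule. Neither step tests a group like the entering one. With compound 3 at 8190 nM as the starting point, a modest move to a lower number is expected in this assay with wide uncertainty. The estimated change is a 2.0-fold lower number from compound 3 to compound 4 (0.31 log units; beyond the scatter) and could prove smaller. For compound 4 the estimate is 4000 nM, with an expected range from 1000 nM to 15000 nM.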

Compound 4, half-maximal inhibitory concentration: > 20000 nM
Compound 4 was reported as a limit; the forecaster's own chance of this, stated with the estimate: 15%; at least 5.0-fold (0.69 log units) between middle value and limit.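

In this assay, 4-chloro-3-(trifluoromethyl)phenyl in place of 3-fluorophenyl on the aromatic nitrogen gave an at least 2.4-fold higher number from compound 3 to compound 4 (0.38 log units; beyond the scatter). Among these compounds, the earlier compounds had only moved a fluoro around the aryl group on this nitrogen, with no change beyond the scatter, so this is the first step showing that a change to this group can shift the read-out beyond the scatter, and it goes towards a weaker inhibitor. Compound 4 stands at a limit of the assay and not a number, and the step is only a floor: the limit of > 20000 nM in this assay, at which 2 of the 4 values shown sit.

The compounds shown leave open whether the chloro, the trifluoromethyl or the two together account for this shift, for neither appears alone on the ring. As far as these compounds go, how an unsubstituted phenyl, or an aryl group bearing an amine or a carboxylic acid, would read on this nitrogen with the core of compound 3 also remains open.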